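Replacing amino with methoxy in compound 2

A few compounds are considered here, and "the series" means these few. Any claim that something is new, unique, unknown or untested is made for them only; others in the source may bear on it.

- compound 1 `CC(Nc1ccccc1Oc1cccc(F)c1)=C1C(=O)CC(c2ccccc2)CC1=O`: 550 nM
- compound 2 `CC(Nc1ccccc1Oc1cccc(N)c1)=C1C(=O)CC(c2ccccc2)CC1=O`: 82 nM

In a functional assay on HeLa cells (Homo sapiens) for antiproliferative activity, read by cell counting, with a stated time of 3 days (on this read-out higher numbers stand for weaker inhibition and lower numbers for stronger inhibition), compound 2 stands lowest of the two at 82 nM. Compound 3 `COc1cccc(Oc2ccccc2NC(C)=C2C(=O)CC(c3ccccc3)CC2=O)c1` differs from it as follows: methoxy in place of amino on an aromatic carbon. Going by the values given here, the only measured step bearing on this change is a 6.7-fold lower number from compound 1 to compound 2 (0.83 log units; beyond the scatter), with amino in place of fluoro. Among the compounds with values here, no methoxy value exists yet, so a higher number is expected, though probably by no more than that step. The expected step is a 3.0-fold higher number from compound 2 to compound 3 (0.48 log units; beyond the scatter). For compound 3 the estimated value is 250 nM, with an expected range of 80 nM to 800 nM.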

Compound 3, half-maximal inhibitory concentration: 93 nM
Estimate against measurement, compound 3: 2.7-fold (0.43 log units) above; measured number inside the range.
By their numbers in this assay, from the lowest: compounds 2 and 3 (each within the scatter of the next); then compound 1.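

In this assay, methoxy and amino prove interchangeable at this position, with a 1.1-fold higher number from compound 2 to compound 3 (0.05 log units; within the scatter), even though methoxy carries 0 hydrogen-bond donors where amino carries 1. Methoxy in place of fluoro gives a 5.9-fold lower number from compound 1 to compound 3 (0.77 log units; beyond the scatter), so the gain over the fluoro compound is not unique to amino. Nothing measured on these compounds accounts for this result.

On these data alone, whether a hydroxyl or a dimethylamino group would stay level with amino and methoxy or fall back towards fluoro remains open. So does the effect of an ethoxy group or a longer chain here.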